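Swapping methoxy for 2,2,2-trifluoroethyl on a side chain

The compounds below may be only part of what the source reports. "The series", "measured", "known", "first", "only" and "open" are said of these compounds alone.

- Compound 1 (`CCn1nc(C(=O)N[C@H]2COc3ccccc3N(C)C2=S)nc1Cc1ccccc1`) 17 nM
- Compound 2 (`CCCn1nc(C(=O)N[C@H]2COc3ccccc3N(C)C2=S)nc1Cc1ccccc1`) 288 nM
- Compound 3 (`COCCn1nc(C(=O)N[C@H]2COc3ccccc3N(C)C2=S)nc1Cc1ccccc1`) 566 nM

In a functional assay on HT-29 cells (Homo sapiens) for inhibition, read by luminescence and CellTiter-Glo, with a stated time of 24 h (a higher number here means that more compound is needed for the effect, a lower number that less compound is needed), compound 3 sits at the high end of these numbers, far from one neighbour (a 33-fold higher number from compound 1 to compound 3 (1.52 log units; beyond the scatter)) and close to the other (a 2.0-fold higher number from compound 2 to compound 3 (0.29 log units; within the scatter)). Compound 4 (`CN1C(=S)[C@@H](NC(=O)c2nc(Cc3ccccc3)n(CCCC(F)(F)F)n2)COc2ccccc21`) shares the core and differs by 2,2,2-trifluoroethyl in place of methoxy on a saturated chain carbon, two bonds along the chain from an aromatic nitrogen on a saturated chain carbon, two bonds along the chain from an aromatic nitrogen. Changes at this carbon bear on it. Adding methyl there gave a large step (a 17-fold higher number from compound 1 to compound 2 (1.23 log units; beyond the scatter)), yet exchanging methyl for methoxy stayed within the scatter. Compound 4 is likewise an exchange, so no step beyond the scatter is expected in this assay, although no fluorinated chain has been measured. The expected step (a 1.1-fold higher number from compound 3 to compound 4 (0.03 log units; within the scatter)) is small. Compound 4 is estimated at 600 nM (range 150 nM to 2400 nM).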

Compound 4, half-maximal effective concentration: 2380 nM
The estimate for compound 4 lay 4.0-fold (0.60 log units) below the measured number, within the range that was stated.
By their numbers in this assay, from the lowest: compound 1; then compounds 2 and 3 (each within the scatter of the next); then compound 4.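

In this assay an exchange at this carbon can matter after all: methyl to methoxy stayed within the scatter, while a 4.2-fold higher number from compound 3 to compound 4 (0.62 log units; beyond the scatter) lies beyond it. Trifluoromethyl in place of hydrogen gives an 8.3-fold higher number from compound 2 to compound 4 (0.92 log units; beyond the scatter) here, and 2,2,2-trifluoroethyl in place of hydrogen gives a 140-fold higher number from compound 1 to compound 4 (2.15 log units; beyond the scatter) overall, the largest step in the set. No measurement is available to explain what sets the fluorinated chain apart.

Still open, as far as these compounds go, is whether an amine or a carboxylic acid on this carbon would bring the number back towards that of compound 1.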